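This account rests on a few compounds, and the source may have more. Where it says the series, first, only, none or still open, it means among the compounds named here.

Compound 1 `COc1cccc(OC)c1C(=O)Nc1c[nH]nc1C(=O)NC1CC1` is one of two compounds tested in an ADME assay on MRC5 cells (Homo sapiens) for inhibition, with a stated time of 72 h; on this read-out higher numbers stand for an effect only at larger amounts of compound and lower numbers for an effect already at smaller amounts. In this assay compound 1 gives > 50000 nM, which is a limit of the assay rather than a number. Compound 2 `CO[C@H]1CC[C@H](NC(=O)c2n[nH]cc2NC(=O)c2ccc(N3CCCC3)cc2)CC1` gives in this assay > 50000 nM, again a limit. Both values therefore sit at the limit of > 50000 nM in this assay, at which 2 of the 2 values shown sit. Compound 3 `COc1cccc(OC)c1C(=O)Nc1c[nH]nc1C(=O)NCc1ccccc1` is not yet measured; it differs from compound 1 by benzyl in place of cyclopropyl on an amide-type nitrogen. Going by the values given here, with no measured step to guide the size, no change beyond the scatter is expected, so the step that the limit leaves unreadable from compound 1 to compound 3 is estimated as flat. Compound 3 is expected near 60000 nM, within 25000 nM to 150000 nM.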

Compound 3, half-maximal effective concentration: 50000 nM
Estimate against measurement, compound 3: 1.2-fold (0.08 log units) above; low and high end bracket the measured number.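

Benzyl in place of cyclopropyl on an amide-type nitrogen gives the first real number of this set, as compound 3 gives 50000 nM and not a limit. The change reads as a number no higher from compound 1 to compound 3 (the limit leaves the size open), so only its direction is visible and its size cannot be read. Most of the values still stand at the edge of the scale: the limit of > 50000 nM in this assay, at which 2 of the 3 values shown sit.

As far as these compounds go, whether an amine or a carboxylic acid on this nitrogen would bring the effect down to smaller amounts stays open. So does whether a longer chain would do so.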